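Piperidin-1-yl for pyrrolidin-1-yl: notes on compound 3

The source may report more compounds than this note shows. Statements on the series, on what has been measured and on what is new or still open speak of the compounds shown alone.

Compound 1 (`C/C1=C\CC[C@@]2(C)O[C@@H]2[C@H]2OC(=O)[C@@H](CN3CCCCC3)[C@@H]2C[C@H]1O`) gives 4000 nM 
Compound 2 (`C/C1=C\CC[C@@]2(C)O[C@@H]2[C@H]2OC(=O)[C@@H](CN3CCCC3)[C@@H]2C[C@@H]1O`) gives 7000 nM 

Going by the values given here, both values come from a functional assay on B16-F10 cells (Mus musculus) for inhibition, read by colorimetric assay and MTT assay, with a stated time of 72 h (a lower number here means a stronger inhibitor, a higher number a weaker inhibitor), and lie within the scatter of each other, so compound 2 cannot be told apart from compound 1 on the numbers so far. Compound 3 (`C/C1=C\CC[C@@]2(C)O[C@@H]2[C@H]2OC(=O)[C@@H](CN3CCCCC3)[C@@H]2C[C@@H]1O`) is still unmeasured and differs from compound 2 in one place: piperidin-1-yl in place of pyrrolidin-1-yl on a saturated chain carbon bound to a saturated ring carbon, with piperidin-1-yl in place of pyrrolidin-1-yl on a saturated chain carbon bound to a saturated ring carbon. Among the compounds with values here, no step between measured compounds is available to size this change. With only compound 1 (4000 nM) and compound 2 (7000 nM) as guides, no step beyond the scatter is expected in this assay. The expected step is a 1.3-fold lower number from compound 2 to compound 3 (0.10 log units; within the scatter) and it stays within the scatter. For compound 3 the estimated value is 5500 nM with an expected range from 2500 nM to 12000 nM in this read-out.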

Compound 3, half-maximal inhibitory concentration: 6000 nM
The estimate for compound 3 lay 1.1-fold (0.04 log units) below the measured number; the range from low to high includes it.
By their numbers in this assay, from the lowest: compounds 1, 3 and 2 (each within the scatter of the next).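

In this assay, piperidin-1-yl in place of pyrrolidin-1-yl on a saturated chain carbon bound to a saturated ring carbon gives a 1.2-fold lower number from compound 2 to compound 3 (0.07 log units; within the scatter), so at this position, with the configuration held constant, the two amines cannot be told apart. The other new comparison concerns the stereocentre at a saturated ring carbon, where a 1.5-fold higher number from compound 1 to compound 3 (0.18 log units; within the scatter) is a step that reads configuration alone: the fact that compounds 1 and 3 differ only in the configuration as drawn. Neither change moves the number beyond the scatter in these compounds, so this series gives no measurable preference for either ring or either drawn configuration.

Going by these compounds, whether morpholin-4-yl or an open-chain dimethylamino group at the same place would give a step beyond the scatter stays open. Also open, on these data alone, is how pyrrolidin-1-yl reads with the configuration of compound 1.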